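Adding methoxy to compound 2: expected step

The compounds below may be only part of what the source reports. "The series", "measured", "known", "first", "only" and "open" are said of these compounds alone.

In a functional assay on A549 cells (Homo sapiens) for antiproliferative activity, read by MTT assay, with a stated time of 48 h (on this read-out lower numbers stand for stronger inhibition and higher numbers for weaker inhibition), compound 1 `Clc1ccc2[nH]c(-c3cn(-c4ccccc4)nc3-c3ccccc3)nc2c1` gives 2370 nM and compound 3 `FC(F)(F)c1ccc2[nH]c(-c3cn(-c4ccccc4)nc3-c3ccc(Cl)cc3)nc2c1` gives 3360 nM as its value. Compound 2 `Clc1cc2nc(-c3cn(-c4ccccc4)nc3-c3ccccc3)[nH]c2cc1Cl` gives 11100 nM as the highest number of the three, beyond the scatter from both others, so it stands at the weak end of this small set.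

Compound 4 `COc1ccc(-c2nn(-c3ccccc3)cc2-c2nc3cc(Cl)c(Cl)cc3[nH]2)cc1` is the next case. Its difference from compound 2 is methoxy in place of hydrogen on an aromatic carbon in one place, methoxy in place of hydrogen on an aromatic carbon, or phenyl to 4-methoxyphenyl.

Within the data shown here, only one measured step is available: a 4.7-fold higher number from compound 1 to compound 2 (0.67 log units; beyond the scatter) for chloro in place of hydrogen on an aromatic carbon. That step is modest and shows that one added group can move this read-out beyond the scatter. However, it involves another group in another place, so it gives a scale and not a direction. Compound 3 differs from compound 2 in more than one place, and no step can be read from it. Among the measured compounds shown here, no measured step covers methoxy.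

No move beyond the scatter is therefore expected, with a slight lean to a lower number, resting on compound 2 at 11100 nM as the top value. The expected step is a 1.5-fold lower number from compound 2 to compound 4 (0.17 log units; within the scatter) as an estimate. For compound 4 the estimated value is 7500 nM (range 2800 nM to 20000 nM).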

Compound 4, half-maximal inhibitory concentration: 7330 nM
Estimate against measurement, compound 4: 1.0-fold (0.01 log units) above, and the stated range covers the measured number.
By their numbers in this assay, from the lowest: compounds 1 and 3 (each within the scatter of the next); then compounds 4 and 2 (each within the scatter of the next).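

In this assay, methoxy in place of hydrogen on an aromatic carbon, on a six-membered aromatic ring of carbon only and para to a large group, gives a 1.5-fold lower number from compound 2 to compound 4 (0.18 log units; within the scatter). Among these compounds, this is the first step measured at this place, and it shows that the change from phenyl to 4-methoxyphenyl, with its added carbon and oxygen, leaves the read-out within the usual scatter, whereas the chloro step elsewhere on the molecule, a 4.7-fold higher number from compound 1 to compound 2 (0.67 log units; beyond the scatter), lies beyond it. Compound 3 also carries a substituent on this ring but differs from compound 2 in more than one place, so no step at this position can be read from it, and no measurement bearing on the reason for the result is available.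

This single step on the dichloro compound leaves open whether methoxy would behave in the same way on compound 1, which has one chloro group. It also leaves open whether a primary amine, a carboxylic acid or a longer chain such as butoxy in the same place would stay within the scatter or move the read-out in either direction.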